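This account rests on a few compounds, and the source may have more. Where it says the series, first, only, none or still open, it means among the compounds named here.

Compound 1 `CC(C)c1ccn2ncnc(N[C@H]3CC[C@H](N(C)C)CC3)c12` is the less lipophilic of the two measured compounds: in a physicochemical assay for lipophilicity, using the shake flask method, at pH 7.4 (on this read-out higher numbers stand for higher lipophilicity and lower numbers for lower lipophilicity), compound 1 gives 1.3, while compound 2 `COC(=O)N1CCN([C@H]2CC[C@H](Nc3ncnn4ccc([C@H](C)CC(=O)N(C)C)c34)CC2)CC1` gives 2.3, a gap that lies beyond the scatter. Compound 3 `CN(C)[C@H]1CC[C@H](Nc2ncnn3ccc([C@H]4CC[C@H](C(N)=O)CC4)c23)CC1` differs from compound 1 in one place (4-carbamoylcyclohexyl in place of isopropyl on an aromatic carbon). Within the data shown here, with no measured pair showing this change, the expectation rests on the structures alone: the step of a number 0.10 log units lower from compound 1 to compound 3 (within the scatter) is expected to be none beyond the scatter, since the added ring and the added amide pull in opposite directions. Compound 3 is therefore estimated at 1.2, within 0.5 to 1.9.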

Compound 3, distribution coefficient: 0.2
Compound 3: the middle estimate sits 1.00 log units above what was measured, outside the stated range (below it).
By their numbers in this assay, from the lowest: compound 3; then compound 1; then compound 2.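

Putting 4-carbamoylcyclohexyl in place of isopropyl on this aromatic carbon gives a number 1.10 log units lower from compound 1 to compound 3 (beyond the scatter) in this assay, so the read-out responds strongly to the group at this position. The change adds carbon atoms and a ring, yet the number falls, so carbon count alone does not set the value in this pair. Nothing shown here explains the drop.

Still open, on these data alone, is which part of the new group carries the step: the cyclohexyl ring or its carbamoyl group. Plain cyclohexyl, or a carboxylic acid or an amine in place of the carbamoyl group, would help separate the two.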